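Three triazole limits and an untested dichlorobenzyl analogue

The source may hold more compounds than are shown below. What is called first, only, known or untested is meant among the compounds shown, and "the series" means these compounds.

The shared core is carried by compound 1 `COc1ccc(CSc2nnc(-c3cc([N+](=O)[O-])cc([N+](=O)[O-])c3)n2Cc2ccccc2)cc1`, compound 2 `O=[N+]([O-])c1cc(-c2nnc(SCc3ccc(Cl)c(Cl)c3)n2Cc2ccccc2)cc([N+](=O)[O-])c1` and compound 3 `COc1ccc(CSc2nnc(-c3cc([N+](=O)[O-])cc(C(F)(F)F)c3)n2Cc2ccccc2)cc1`. In an ADME assay on A-431 cells (Homo sapiens) for cytotoxicity, with a stated time of 48 h (a lower number here means a stronger inhibitor, a higher number a weaker inhibitor), compound 1 gives only a limit of the assay, > 30000 nM. Compound 2 likewise gives a limit in this assay, > 30000 nM. Compound 3 also stands at a limit in this assay, > 30000 nM, so its place among the values shown is a limit, not a number. The step that the two limits leave unreadable from compound 1 to compound 2 and the step that the two limits leave unreadable from compound 1 to compound 3 are therefore unreadable.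

Compound 4 `O=[N+]([O-])c1cc(-c2nnc(SCc3ccc(Cl)c(Cl)c3)n2Cc2ccccc2)cc(C(F)(F)F)c1` differs from compound 3 in one place: 3,4-dichlorophenyl in place of 4-methoxyphenyl on a saturated chain carbon bound to a sulfur. Among the measured compounds shown here, the only measured step of the same kind is from compound 1 to compound 2, and it is unreadable because of the limit of > 30000 nM in this assay, at which 3 of the 3 values shown sit. For the measured compounds named here, no measured step therefore shows a direction; what the two limits show is consistent with no readable change. The estimate for compound 4 in this assay is 40000 nM, between 15000 nM and 100000 nM, and the expected step that the limit leaves unreadable from compound 3 to compound 4 is most likely again hidden behind a limit.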

Compound 4, half-maximal inhibitory concentration: > 30000 nM
Compound 4 ended at the assay's limit; the forecaster's own chance of this, stated with the estimate: 80%; the middle value lies beyond the limit too.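

In this assay compound 4 gives > 30000 nM, which is a limit of the assay. Its steps from compound 3 and from compound 2 therefore cannot be read: the limit of > 30000 nM in this assay, at which 4 of the 4 values shown sit.

The compounds shown leave open whether either exchange changes the read-out in this assay at all.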